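The source may hold more compounds than are shown below. What is called first, only, known or untested is meant among the compounds shown, and "the series" means these compounds.

Compound 1 `O=C1CC[C@@H](C(=O)N2CCC(NS(=O)(=O)c3cc(S(=O)(=O)c4ccccc4)ccc3C(F)(F)F)CC2)N1` is the starting point. In an assay on isolated protein for binding affinity to secreted frizzled-related protein 1 (Homo sapiens), read by fluorescence (a lower number here means a stronger inhibitor, a higher number a weaker inhibitor), compound 1 gives 90 nM, the highest number among the three compounds measured, so it is the weakest of them. Compound 2 `CC(C)(C)C(=O)N1CCC[C@H]1C(=O)N1CCC(NS(=O)(=O)c2cc(S(=O)(=O)c3ccccc3)ccc2C(F)(F)F)CC1` gives 40 nM in this assay, and compound 3 `CN(C)C(=O)N1CCC[C@H]1C(=O)N1CCC(NS(=O)(=O)c2cc(S(=O)(=O)c3ccccc3)ccc2C(F)(F)F)CC1` gives 30 nM. The step of a 2.3-fold lower number from compound 1 to compound 2 (0.35 log units; beyond the scatter) and the step of a 3.0-fold lower number from compound 1 to compound 3 (0.48 log units; beyond the scatter) point the same way, while a 1.3-fold lower number from compound 2 to compound 3 (0.12 log units; within the scatter) shows that the two different groups on the ring nitrogen give numbers within the scatter of each other.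

Compound 4 `CN1CCC[C@H]1C(=O)N1CCC(NS(=O)(=O)c2cc(S(=O)(=O)c3ccccc3)ccc2C(F)(F)F)CC1` differs from compound 1 as follows: 1-methylpyrrolidin-2-yl in place of 5-oxopyrrolidin-2-yl on a carbonyl carbon. The 5-oxopyrrolidin-2-yl group leaves here just as it does in the two measured steps, and the ring nitrogen now carries only a methyl. Both measured steps away from compound 1 were modest improvements, so a similar or somewhat smaller gain is expected, which would give a 1.6-fold lower number from compound 1 to compound 4 (0.21 log units; within the scatter). Compound 4 is therefore estimated at 55 nM in this assay, with a likely range from 25 nM to 150 nM.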

Compound 4, half-maximal inhibitory concentration: 120 nM
For compound 4 the middle estimate is 2.2-fold (0.34 log units) below the measured one; the range from low to high includes it.
By their numbers in this assay, from the lowest: compounds 3 and 2 (each within the scatter of the next); then compounds 1 and 4 (each within the scatter of the next).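

In this assay, a 1.3-fold higher number from compound 1 to compound 4 (0.12 log units; within the scatter) is the step for putting 1-methylpyrrolidin-2-yl in place of 5-oxopyrrolidin-2-yl on this carbonyl carbon, so these two groups cannot be told apart here. The group on the pyrrolidine ring nitrogen is what separates the compounds: methyl in place of dimethylcarbamoyl gives a 4.0-fold higher number from compound 3 to compound 4 (0.60 log units; beyond the scatter) and methyl in place of (tert-butyl)carbonyl gives a 3.0-fold higher number from compound 2 to compound 4 (0.48 log units; beyond the scatter) in this series, so the lower numbers of compounds 2 and 3 go with those two carbonyl-linked groups rather than with the pyrrolidine ring itself. Nothing available here accounts for these differences.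

On these data alone, it remains open whether a smaller carbonyl group on that nitrogen, such as acetyl, would match compounds 2 and 3. As far as these compounds go, it is also open whether a free amine or a longer chain such as ethyl would give numbers like that of compound 4.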